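From compound 2 to compound 4: a step without an anchor

A few compounds are considered here, and "the series" means these few. Any claim that something is new, unique, unknown or untested is made for them only; others in the source may bear on it.

Measured in an ADME assay on Vero cells (Chlorocebus sabaeus) for cytotoxicity, read by MTT assay, with a stated time of 72 h; a lower number here means that less compound is tolerated, a higher number that more compound is tolerated:
- compound 1 `COc1cccc(-c2cc(-c3ccc(C4NC(=O)c5ccccc5N4)cc3)nc(N)n2)c1OC`: > 400000 nM (a limit of the assay)
- compound 2 `Nc1nc(-c2ccccc2)cc(-c2ccc(C3NC(=O)c4ccccc4N3)cc2)n1`: "not determined" (no result reported)
- compound 3 `COc1cc(-c2cc(-c3ccc(C4NC(=O)c5ccccc5N4)cc3)nc(N)n2)cc(OC)c1OC`: 85900 nM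

Compound 2 has no number to stand on, and its entry reads "not determined" (no result reported). The step to compound 4 `CN1CCN(c2ccc(-c3cc(-c4ccc(C5NC(=O)c6ccccc6N5)cc4)nc(N)n3)cc2)CC1` is 4-methylpiperazin-1-yl in place of hydrogen on an aromatic carbon, para to a large group. Going by the values given here, no step from compound 2 was measured, so its size cannot be read directly. Among the compounds with values here, the one measured step that bears on it also exchanges groups on an aromatic carbon, and it is an at least 4.6-fold lower number from compound 1 to compound 3 (0.66 log units; beyond the scatter). Compound 1 stands at the limit of > 400000 nM in this assay, at which 1 of the 3 values shown sits, so that step is only a bound. Within the data shown here, compound 3, at 85900 nM, gives the only true number here, and compound 4 is expected to land near it, on the side of less compound tolerated. A step of similar size towards a lower number is therefore expected. For compound 4 the expected value in this assay is 60000 nM, with an estimated range from 15000 nM to 250000 nM.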

Compound 4, half-maximal cytotoxic concentration: 8320 nM
Compound 4: middle estimate off by 7.2-fold (0.86 log units), on the high side; measured number below the stated range.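

Compound 2 has no reported result in this assay, so the step from compound 2 to compound 4 cannot be read. The compounds shown leave open how much of the number for compound 4 goes with the 4-methylpiperazin-1-yl group in place of hydrogen.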